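The compounds below may be only part of what the source reports. "The series", "measured", "known", "first", "only" and "open" are said of these compounds alone.

Working notes on the series, read in a physicochemical assay for solubility (a lower number here means a less soluble compound, a higher number a more soluble compound), with two compounds on the shared core so far. Compound 1 `CS(=O)(=O)c1ccc(-n2nc(C(F)F)c(C#N)c2-c2ccccc2)nc1` returned "not determined" (no result reported) in this assay and so adds nothing to the scale. Compound 2 `C[C@@H]1CN(c2c(C#N)c(C(F)F)nn2-c2ccc(S(C)(=O)=O)cn2)[C@H](C)CO1` gives > 200 ug/mL as its reading, and that is a limit, not a number. Among the compounds with values here, it is the only reading in hand, so compound 2 stands at the limit of > 200 ug/mL in this assay, at which 1 of the 2 values shown sits, with no true value behind it.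

Compound 3 `CS(=O)(=O)c1ccc(-n2nc(C(F)F)c(C#N)c2NC2CCCC2)nc1` alters one place on the core of compound 2 (a group of 6 heavy atoms (5 carbon, 1 nitrogen; one five-membered non-aromatic ring of carbon only) in place of a group of 8 heavy atoms (6 carbon, 1 nitrogen, 1 oxygen; one six-membered non-aromatic ring with 2 hetero atoms), on an aromatic carbon) and keeps the rest. The cyclopentylamino group enters on an aromatic carbon, where the six-membered non-aromatic ring with 2 hetero atoms leaves. Within the data shown here, no measured step gives a size for such a change. Among the measured compounds shown here, the expected step (an at least 4.0-fold lower number from compound 2 to compound 3 (0.60 log units; beyond the scatter)) is a fall beyond the scatter, and its size is a judgement with no measured step behind it. For compound 3 the estimated value is 50 ug/mL within an expected range from 10 ug/mL to 200 ug/mL on repeat measurement.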

Compound 3, solubility: 25 ug/mL
Compound 3: middle estimate off by 2.0-fold (0.30 log units), on the high side; the range from low to high includes it.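

In this assay, cyclopentylamino in place of the six-membered non-aromatic ring with 2 hetero atoms, on this aromatic carbon of the five-membered aromatic ring, gives an at least 8.0-fold lower number from compound 2 to compound 3 (0.90 log units; beyond the scatter). Within the data shown here, this is the first measured step, and it shows that the reading responds to a change at this position, with compound 3 giving the first true number on the scale. The full size of the step stays unfixed, since the comparison starts from a limit and not a number: the limit of > 200 ug/mL in this assay, at which 1 of the 3 values shown sits.

The change alters the ring, its hetero atoms, the hydrogen-bond donor count and the defined stereocentres all at once, and the compounds shown do not separate these features, so no single one can be tied to the fall. From the compounds shown here alone, how a piperidine or a simple dialkylamine on the same aromatic carbon would read in this assay remains open, as does whether the step seen here would hold with another group at this position.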